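The source may report more compounds than this note shows. Statements on the series, on what has been measured and on what is new or still open speak of the compounds shown alone.

Going by the values given here, compound 1 `Cc1nc(SCC(=O)Nc2nc(-c3ccc(Cl)cc3)cs2)n(Nc2ccccc2)c1C` is the only member of this series with a numeric value: in a functional assay on SW-620 cells (Homo sapiens) for antiproliferative activity, read by sulforhodamine B assay, with a stated time of 48 h (on this read-out higher numbers stand for lower toxicity in this test and lower numbers for higher toxicity in this test), compound 1 gives 74600 nM. Compound 2 `Cc1ccc(Nn2c(SCC(=O)Nc3nc(-c4ccccc4)cs3)nc(C)c2C)cc1` reaches only a limit, since in this assay compound 2 gives > 100000 nM, which marks the edge of the assay rather than a number; this is the same boundary noted in the limit of > 100000 nM in this assay, at which 1 of the 2 values shown sits. Compound 3 `COc1ccc(Nn2c(SCC(=O)Nc3nc(-c4ccc(Cl)cc4)cs3)nc(C)c2C)cc1` is the compound not yet measured. It differs from compound 1 by methoxy in place of hydrogen on an aromatic carbon. Among the compounds with values here, no measured pair shows this change, so the step from compound 1 to compound 3 in this assay is expected to be small, a 1.1-fold higher number from compound 1 to compound 3 (0.06 log units; within the scatter), none clearly beyond the scatter. Compound 3 is therefore expected to give about 85000 nM in this assay, between 35000 nM and 200000 nM.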

Compound 3, concentration lethal to 50% of the cells: > 100000 nM
Compound 3: only a limit was reported; the forecaster's own chance of this, stated with the estimate: 45%; at least 1.1-fold (0.07 log units) between middle value and limit.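

The change from anilino to (4-methoxyphenyl)amino gives the first step read at this position in this assay, with an at least 1.3-fold higher number from compound 1 to compound 3 (0.12 log units; that floor lies within the scatter). That floor does not separate the two compounds, so methoxy at this aromatic carbon is not shown to shift the read-out beyond the usual scatter. The value of compound 3 is a limit, and the series now gathers at that edge: the limit of > 100000 nM in this assay, at which 2 of the 3 values shown sit.

As far as these compounds go, how far past the limit compound 3 lies remains open. So does whether an amine or a carboxylic acid at this carbon would give a numeric value.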